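This account rests on a few compounds, and the source may have more. Where it says the series, first, only, none or still open, it means among the compounds named here.

Measured compounds:
Compound 1 `CC(C)(C)OC(=O)N1CCC(CCCNc2ccc3c(c2)OCC3=O)CC1` gives 66 nM in a functional assay on CHO-K1 cells for agonist activity at Glucose-dependent insulinotropic receptor (Mus musculus), read by HTRF and cAMP accumulation, with a stated time of 30 min; on this read-out higher numbers stand for an effect only at larger amounts of compound and lower numbers for an effect already at smaller amounts.
Compound 2 `CC(C)(C)OC(=O)N1CCC(CCCNc2ccc3c(c2)C(=O)CO3)CC1` gives 262 nM in this assay.
Compound 3 `CC(C)(C)OC(=O)N1CCC(CCCNc2ccc3c(c2)C(=O)NC3)CC1` gives 892 nM in this assay.

Among these three, compound 1 has the lowest number; compound 2 and compound 3 both sit higher, each beyond the usual scatter. Compound 4 `COC(=O)c1cnc(N2CCC(CCCNc3ccc4c(c3)OCC4=O)CC2)nc1` keeps the whole of compound 1 apart from one change: 5-(methoxycarbonyl)pyrimidin-2-yl in place of tert-butoxycarbonyl on an amine nitrogen in a ring. Within the data shown here, no measured pair shows what such an exchange on this ring nitrogen does, so its effect is an open question. Lacking such a comparison, the expected step from compound 1 to compound 4 in this assay is only a small one, a 1.5-fold lower number from compound 1 to compound 4 (0.17 log units; within the scatter), with either direction possible. Compound 4 is therefore estimated at 45 nM, within a range from 8 nM to 250 nM.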

Compound 4, half-maximal effective concentration: 139 nM
Compound 4: the middle estimate sits 3.1-fold (0.49 log units) below what was measured; the range from low to high includes it.
By their numbers in this assay, from the lowest: compound 1; then compounds 4 and 2 (each within the scatter of the next); then compound 3.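

Placing 5-(methoxycarbonyl)pyrimidin-2-yl instead of tert-butoxycarbonyl on this ring nitrogen gives a 2.1-fold higher number from compound 1 to compound 4 (0.32 log units; beyond the scatter) in this assay, a modest loss. So the carbamate-type tert-butoxycarbonyl group is not essential here: a group carrying a six-membered aromatic ring still gives activity at this position. Nothing shown explains the size of this step.

From the compounds shown here alone, it remains open whether a carboxylic acid or a primary amide in place of the methoxycarbonyl would lower or raise the number. Going by these compounds, it is also open whether the same exchange would behave alike on the cores of compound 2 and compound 3.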